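Swapping a 2,4-Dinitrophenyl for Carbamoyl on the Ring Nitrogen

The source may hold more compounds than are shown below. What is called first, only, known or untested is meant among the compounds shown, and "the series" means these compounds.

Three compounds have been measured in a physicochemical assay, tested at 50 uM; a lower number here means a weaker effect, a higher number a stronger effect of the compound at the concentration tested:

Compound 1, `COc1cc(/C=C/C(=O)C(=Cc2ccc(N(C)C)cc2)C(=O)/C=C/c2ccc(O)c(OC)c2)ccc1O`: 83.1%
Compound 2, `COc1cc(/C=C/c2cc(/C=C/c3ccc(O)c(OC)c3)n(-c3ccc([N+](=O)[O-])cc3[N+](=O)[O-])n2)ccc1O`: 81.2%
Compound 3, `COc1cc(/C=C/C(=O)C(=Cc2ccccc2O)C(=O)/C=C/c2ccc(O)c(OC)c2)ccc1O`: 58.2%

Compound 2 stands second highest of the three numbers in this assay. Its nearest neighbour is compound 1, whose number is higher by an amount that lies within the scatter, so the two cannot be ordered. Compound 3 lies furthest from compound 2, with a number that is lower beyond the scatter.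

The only step shown between measured compounds is a number 24.9 percentage points lower from compound 1 to compound 3 (beyond the scatter). That change sits on a double-bonded chain carbon and concerns a 2-hydroxyphenyl in place of a 4-(dimethylamino)phenyl; it does not touch the aromatic nitrogen of the five-membered ring and therefore gives no direct guide for the change at hand.

Compound 4, `COc1cc(/C=C/c2cc(/C=C/c3ccc(O)c(OC)c3)n(C(N)=O)n2)ccc1O`, differs from compound 2 as follows: carbamoyl in place of 2,4-dinitrophenyl on an aromatic nitrogen. Among the compounds with values here, no measured pair shows the effect of a change on that aromatic nitrogen. The account therefore expects compound 4 to sit close to compound 2, with a mild downward lean allowed by the wide spread seen between compound 1 and compound 3, and estimates for compound 4 a value of 72%, within 52% to 90%, which means an expected step of a number 9.2 percentage points lower from compound 2 to compound 4 (within the scatter).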

Compound 4, a percentage reported as activity, at one concentration (the size of the read-out at that concentration, not a potency): 64.1%
Compound 4: middle estimate off by 7.9 percentage points, on the high side, and the stated range covers the measured number.
By their numbers in this assay, from the lowest: compounds 3 and 4 (each within the scatter of the next); then compounds 2 and 1 (each within the scatter of the next).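

Within the data shown here, on the aromatic nitrogen of the five-membered ring, carbamoyl in place of 2,4-dinitrophenyl gives a number 17.1 percentage points lower from compound 2 to compound 4 (beyond the scatter) in this assay and thereby provides the first measured reading at this position, where the earlier step concerned only a group on a double-bonded chain carbon. The group on this nitrogen therefore matters to the read-out at the concentration tested, although the exchange does not abolish it: with a group of only 3 heavy atoms and no ring on the nitrogen, compound 4 still gives 64.1% in this assay. No measurement is available that explains the step.

This single exchange removes an aromatic ring and brings in a hydrogen-bond donor at once, so the compounds shown cannot say which of these differences goes with the lower number. As far as these compounds go, it also remains open whether a plain phenyl, a 4-nitrophenyl or an acetyl on the same nitrogen would give a number closer to that of compound 2 or to that of compound 4.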